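Chalcone aryl swap on the imidazolone series

The compounds below may be only part of what the source reports. "The series", "measured", "known", "first", "only" and "open" are said of these compounds alone.

Measured so far:
- compound 1, `COc1cc(/C=C/C(=O)c2cccc(-n3cc(-c4ccc(Cl)cc4)[nH]c3=O)c2)cc(OC)c1OC`, 2140 nM
- compound 2, `COc1ccc(-c2cn(-c3cccc(C(=O)/C=C/c4ccc(O)c(OC)c4)c3)c(=O)[nH]2)cc1`, 4530 nM

Both numbers come from a functional assay on 786-0 cells (Homo sapiens) for inhibition; on this read-out higher numbers stand for weaker inhibition of growth and lower numbers for stronger inhibition of growth. Compound 2 stands at the higher of the two numbers; compound 1 is the nearest, and the gap between them lies beyond the scatter. Among the compounds with values here, the two differ in more than one place, so the numbers show only that compound 1 sits lower than compound 2, not which change is responsible.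

Compound 3, `COc1ccc(-c2cn(-c3cccc(C(=O)/C=C/c4cc(OC)c(OC)c(OC)c4)c3)c(=O)[nH]2)cc1`, has not been measured. Relative to compound 2 the change is 3,4,5-trimethoxyphenyl in place of 4-hydroxy-3-methoxyphenyl on a double-bonded chain carbon bound to a double-bonded chain carbon. Within the data shown here, no single-point step between measured compounds is available to calibrate this change. Compound 1 carries the same 3,4,5-trimethoxyphenyl group and gives 2140 nM, which points toward a somewhat lower number for compound 3, but the other difference between compound 1 and compound 2 blurs that reading.

The expected step from compound 2 to compound 3 in this assay is a modest decrease, a 1.7-fold lower number from compound 2 to compound 3 (0.24 log units; within the scatter), close to the edge of the scatter. Compound 3 is estimated at 2600 nM, within 1000 nM to 7000 nM.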

Compound 3, concentration for 50% growth inhibition: 1610 nM
For compound 3 the middle estimate is 1.6-fold (0.21 log units) above the measured one; measured number inside the range.
By their numbers in this assay, from the lowest: compounds 3 and 1 (each within the scatter of the next); then compound 2.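

In this assay, the change to 3,4,5-trimethoxyphenyl in place of 4-hydroxy-3-methoxyphenyl on a double-bonded chain carbon bound to a double-bonded chain carbon now has a single-place reading, and it lies beyond the scatter (a 2.8-fold lower number from compound 2 to compound 3 (0.45 log units; beyond the scatter)). With 3,4,5-trimethoxyphenyl held constant, methoxy in place of chloro on an aromatic carbon stays within the scatter (a 1.3-fold lower number from compound 1 to compound 3 (0.12 log units; within the scatter)), so this exchange does not separate the two compounds in this assay. Across these three compounds, the gap first seen between compound 1 and compound 2 therefore follows the chain aryl group, while the chloro and methoxy compounds with 3,4,5-trimethoxyphenyl remain indistinguishable. No measurement is available that explains the step.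

Still open, from the compounds shown here alone, is whether the step follows the loss of the hydroxy group or the gain of the added methoxy group, since the two changes arrive together in compound 3. Also open, going by these compounds, is how this position responds to groups of a different kind on the aryl ring, such as an amine, a carboxylic acid or a longer alkoxy chain in place of methoxy.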